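Acetyl for Ethyl on a Ring Amine Nitrogen

This account rests on a few compounds, and the source may have more. Where it says the series, first, only, none or still open, it means among the compounds named here.

Of the compounds shown here, three that share one core have been measured in an assay on HEK293 cells for negative allosteric modulation of metabotropic glutamate receptor 5 (Homo sapiens), read by FLIPR, with a stated time of 1 h; a higher number here means a weaker inhibitor, a lower number a stronger inhibitor. Compound 1 `Cc1cccc(C#Cc2nc3c(s2)C(=O)NCC3)c1` reaches only the limit of the assay, > 10000 nM, and returns no number. Compound 2 `CN1CCc2nc(C#Cc3cccc(F)c3)sc2C1` likewise gives only the limit, > 10000 nM, without a number. Going by the values given here, compound 3 `CCN1CCc2nc(C#Cc3ccccc3)sc2C1` is the one compound with a measured number, giving 1200 nM in this assay. It therefore stands as the only number shown, since (the limit of > 10000 nM in this assay, at which 2 of the 3 values shown sit).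

Compound 4 `CC(=O)N1CCc2nc(C#Cc3ccccc3)sc2C1` has not yet been measured. It differs from compound 3 in one place: acetyl in place of ethyl on an amine nitrogen in a ring. Among the compounds with values here, no pair of measured compounds differs in just this way, so no measured step guides the expectation, and the two compounds sitting at the limit differ from compound 3 in more than one place. In this assay the step of a 2.9-fold higher number from compound 3 to compound 4 (0.46 log units; beyond the scatter) is expected, toward a weaker inhibitor and somewhat beyond the usual scatter. The estimate for compound 4 in this assay is 3500 nM, with a range from 800 nM to 15000 nM, and there is a real chance that compound 4 also returns only a limit.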

Compound 4, half-maximal inhibitory concentration: 90 nM
Beside the measured number, compound 4's estimate is 39-fold (1.59 log units) above it; the measured number lies below the stated range.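

In this assay the amine nitrogen in the ring proves to be a place where the choice of group counts heavily: acetyl in place of ethyl gives a 13-fold lower number from compound 3 to compound 4 (1.12 log units; beyond the scatter), so the entering group, with its carbonyl and its hydrogen-bond acceptor, goes with the stronger inhibitor here. Until now the shared core carried a single number, so no change at this nitrogen could be read; this step is the only one that can be read, and the others cannot because so many of the values are limits: the limit of > 10000 nM in this assay, at which 2 of the 4 values shown sit. The data give no cause for the size of the step, and they rest on this one pair alone.

On these data alone, whether the step belongs to the carbonyl as such stays open, since a propanoyl group, a methyl carbamate, a urea or a sulfonamide on the same nitrogen could each read differently from acetyl. As far as these compounds go, it is also open whether the step would carry over to compounds bearing the fluoro group of compound 2 or the methyl group of compound 1.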